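Methyl removal on the shared core: outlook for compound 4

A few compounds are considered here, and "the series" means these few. Any claim that something is new, unique, unknown or untested is made for them only; others in the source may bear on it.

The series keeps one core and varies the methoxyphenyl group and a methyl on the core. Compound 1 `COc1ccc(-c2cc(O)c3cccnc3n2)cc1` carries no methyl on the core; in a functional assay on OVCAR-3 cells (Homo sapiens) (on this read-out higher numbers stand for weaker inhibition of growth and lower numbers for stronger inhibition of growth), compound 1 gives 30200 nM. Compound 3 `COc1ccc(-c2cc(O)c3cc(C)cnc3n2)cc1` carries a methyl on the core, and in this assay compound 3 gives 2950 nM. Compound 2 `COc1ccccc1-c1cc(O)c2ccc(C)nc2n1` has the same atoms as compound 3, joined differently; in this assay compound 2 reaches only a limit of the assay, > 100000 nM. How the core of compound 2 differs from that of compound 3 is not broken down here.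

The measured step of a 10-fold higher number from compound 3 to compound 1 (1.01 log units; beyond the scatter) is hydrogen in place of methyl on an aromatic carbon. Compound 4 `COc1ccccc1-c1cc(O)c2cccnc2n1` stands to compound 2 as compound 1 stands to compound 3: hydrogen in place of methyl on an aromatic carbon. The place of the change is not the same word for word: in compound 3 the methyl sits two atoms from the ring nitrogen, in compound 2 next to the ring nitrogen, so this counts as the same kind of change rather than the same change.

For compound 4 the expected step is a number no higher from compound 2 to compound 4 (the limit leaves the size open), resting on the measured 10-fold higher number from compound 3 to compound 1 (1.01 log units; beyond the scatter) and on the limit of > 100000 nM in this assay, at which 1 of the 3 values shown sits, at which compound 2 sits. Compound 4 is therefore expected near 100000 nM, between 30000 nM and 300000 nM, and the assay may again report only a limit.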

Compound 4, concentration for 50% growth inhibition: 47900 nM
Beside the measured number, compound 4's estimate is 2.1-fold (0.32 log units) above it, within the range that was stated.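

In this assay, hydrogen in place of methyl on an aromatic carbon gives an at least 2.0-fold lower number from compound 2 to compound 4 (0.31 log units; beyond the scatter), whereas the same kind of change earlier gave a 10-fold higher number from compound 3 to compound 1 (1.01 log units; beyond the scatter). The two steps run in opposite directions, so in this series the change does not carry from one core to the other with either its sign or its size: the same change on two cores in this assay, a 10-fold higher number (1.01 log units; beyond the scatter) from compound 3 to compound 1 and an at least 2.0-fold lower number (0.31 log units; beyond the scatter) from compound 2 to compound 4, at least 21-fold (1.32 log units) apart, beyond the scatter of two such steps This does not show what sets the reversal, since the methyl and the methoxy group both sit differently in the two pairs and neither difference is separated from the other, and the limit of compound 2 gives the step a bound rather than a size: the limit of > 100000 nM in this assay, at which 1 of the 4 values shown sits.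

Open, going by these compounds, is whether the step follows the place of the methyl on the core or the place of the methoxy group on the phenyl ring, which would need pairs in which only one of the two differs. Also open, on these data alone, is whether a longer chain such as ethyl, or an amine, in the place of the methyl would follow the pattern of compound 3 or that of compound 2.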